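Shortening the Alkoxy Chain from Butyl to Ethyl

A few compounds are considered here, and "the series" means these few. Any claim that something is new, unique, unknown or untested is made for them only; others in the source may bear on it.

Compound 3 `CCCCOc1ccccc1C1CC(=O)c2ccccc2O1` stands second highest of the three measured numbers in a functional assay on J774.A1 cells (Mus musculus) for inhibition, read by immunoassay, with a stated time of 12 h, tested at 30 uM (on this read-out higher numbers stand for more inhibition at the one concentration tested (going by the name of the read-out) and lower numbers for less inhibition), where compound 3 gives 42.5%. Compound 1 `CC(C)c1ccc(COc2ccccc2C2CC(=O)c3ccccc3O2)cc1` gives 91.7% in this assay, and the step of a number 49.2 percentage points lower from compound 1 to compound 3 (beyond the scatter) is large. Compound 2 `CCCCCOc1ccccc1C1CC(=O)c2ccccc2O1` gives 40.1%, and the step of a number 2.4 percentage points higher from compound 2 to compound 3 (within the scatter) lies within the scatter. The step of a number 51.6 percentage points lower from compound 1 to compound 2 (beyond the scatter) is likewise a large drop.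

Compound 4 `CCOc1ccccc1C1CC(=O)c2ccccc2O1` differs from compound 3 by hydrogen in place of ethyl on a saturated chain carbon, two bonds along the chain from an oxygen on an aromatic ring. Within the data shown here, the measured step that bears on this change is the one from compound 2 to compound 3, where a chain was shortened by one carbon and the step of a number 2.4 percentage points higher from compound 2 to compound 3 (within the scatter) stayed within the scatter. The large steps from compound 1 concern the exchange of an aromatic group for a chain and say nothing about a further shortening of that chain. Among the measured compounds shown here, no measured compound carries a chain as short as ethyl, so the expectation rests on a single step.

On that basis compound 4 is expected to give 40% in this assay, with a range from 25% to 55%. The expected step of a number 2.5 percentage points lower from compound 3 to compound 4 (within the scatter) is therefore small and within the scatter.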

Compound 4, a percentage reported as inhibition, at one concentration (the size of the read-out at that concentration, not a potency): 27.7%
Compound 4: middle estimate off by 12.3 percentage points, on the high side, and the stated range covers the measured number.
By their numbers in this assay, from the lowest: compound 4; then compounds 2 and 3 (each within the scatter of the next); then compound 1.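

Shortening the chain at this position is not without consequence after all: in this assay the change from butoxy to ethoxy brings the step of a number 14.8 percentage points lower from compound 3 to compound 4 (beyond the scatter), whereas the earlier shortening gave only the step of a number 2.4 percentage points higher from compound 2 to compound 3 (within the scatter). The longer chain of compound 2 stands apart from the ethoxy chain in the same way, with the step of a number 12.4 percentage points lower from compound 2 to compound 4 (beyond the scatter), so among these three chains the read-out does not fall evenly with length but separates compound 4 from the other two. The step of a number 64 percentage points lower from compound 1 to compound 4 (beyond the scatter) is the widest yet seen in this series and sets the ethoxy compound furthest from the compound carrying 4-isopropylphenyl on the chain carbon bound to the oxygen.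

Nothing at hand explains why the number falls at this chain length. Still open, going by these compounds, is whether a methoxy group would lower the number further, whether a hexyloxy chain would stay level with compound 2, and whether an amine at the chain end or a plain benzyl group would recover any of the inhibition seen with compound 1.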